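The compounds below may be only part of what the source reports. "The series", "measured", "known", "first", "only" and "open" are said of these compounds alone.

Of the compounds shown here, three sharing one core have been measured in a functional assay on HeLa cells (Homo sapiens) for inhibition, read by MTT assay, with a stated time of 48 h (a higher number here means a weaker inhibitor, a lower number a stronger inhibitor), and differ only in one group on an amine nitrogen. Compound 1 `CCOC(=O)C1=C(NN=C(C(C)=O)C(C)=O)Nc2[nH]nc(C)c2C1c1ccc(N(C)C)cc1` reads 17000 nM while compound 2 `CCOC(=O)C1=C(N/N=C(/C#N)C(=O)OCC)Nc2[nH]nc(C)c2C1c1ccc(N(C)C)cc1` reads 39200 nM and compound 3 `CCOC(=O)C1=C(N/N=C(/C(=O)Br)c2ccc(Br)cc2)Nc2[nH]nc(C)c2C1c1ccc(N(C)C)cc1` reads 68500 nM on this scale. Compound 3 cannot be separated from compound 2 (a 1.7-fold higher number from compound 2 to compound 3 (0.24 log units; within the scatter)) but stands clear of compound 1 (a 4.0-fold higher number from compound 1 to compound 3 (0.61 log units; beyond the scatter)). The change to compound 4 `CCOC(=O)C1=C(NN=C(C#N)C#N)Nc2[nH]nc(C)c2C1c1ccc(N(C)C)cc1` is a group of 6 heavy atoms (3 carbon, 3 nitrogen; no ring) in place of a group of 12 heavy atoms (8 carbon, 1 nitrogen, 1 oxygen, 2 bromine; one six-membered aromatic ring of carbon only), on an amine nitrogen and removes the ring, so the new group is ring-free like those of compound 1 and compound 2. The closest guide is the modest step (a 4.0-fold higher number from compound 1 to compound 3 (0.61 log units; beyond the scatter)), though compound 2 goes against it, showing no gap beyond the scatter from compound 3 (a 1.7-fold higher number from compound 2 to compound 3 (0.24 log units; within the scatter)) and itself sitting apart from compound 1 (a 2.3-fold higher number from compound 1 to compound 2 (0.36 log units; beyond the scatter)). A modest move towards a lower number is therefore expected, with an estimated 2.7-fold lower number from compound 3 to compound 4 (0.44 log units; beyond the scatter) in this assay as the result. Compound 4 is estimated at 25000 nM with 9000 nM to 70000 nM as its expected range.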

Compound 4, half-maximal inhibitory concentration: 15200 nM
The estimate for compound 4 lay 1.6-fold (0.22 log units) above the measured number, and the stated range covers the measured number.
By their numbers in this assay, from the lowest: compounds 4 and 1 (each within the scatter of the next); then compounds 2 and 3 (each within the scatter of the next).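

In this assay, replacing the group that carries the aromatic ring on this amine nitrogen with the ring-free group of compound 4 gives a step beyond the scatter (a 4.5-fold lower number from compound 3 to compound 4 (0.65 log units; beyond the scatter)). Losing the ring does not settle the number by itself: two ring-free groups still stand apart (a 2.6-fold lower number from compound 2 to compound 4 (0.41 log units; beyond the scatter)), while another ring-free pair cannot be told apart (a 1.1-fold lower number from compound 1 to compound 4 (0.05 log units; within the scatter)), so the identity of the ring-free group matters at this position. No measurement available here explains these differences.

Among these compounds, compound 3 is the only compound here with a ring in this group, and that ring carries bromine, so the ring and the halogen cannot be judged separately. Where a plain phenyl group, or a ring-free chain ending in an amine or a carboxylic acid, would fall on this scale remains open.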